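Changing the amide substituent on a shared dihydropyridine-free core

A few compounds are considered here, and "the series" means these few. Any claim that something is new, unique, unknown or untested is made for them only; others in the source may bear on it.

Three compounds share the same core and differ only in the group carried by the amide-type nitrogen of a side chain. Compound 1 `CCOC(=O)C1=C(C)NC(C)=C(C(=O)OCC)C1c1ccc(OCC(=O)Nc2ccc(C)cc2)cc1` carries a 4-methylphenyl there. In a functional assay on the whole organism (strain Wistar) for inhibition, with Rattus norvegicus as the target, read by paw edema, with stated times of 30 min and 2 h, at a dose of 20 mg/kg (a lower number here means less inhibition, a higher number more inhibition at the dose given (going by the name of the read-out)), compound 1 gives 62.2%. Compound 2 `CCOC(=O)C1=C(C)NC(C)=C(C(=O)OCC)C1c1ccc(OCC(=O)NNC(=O)c2cccs2)cc1` carries a ((thiophen-2-yl)carbonyl)amino instead and gives 62.2%, so no change at the digits printed from compound 1 to compound 2 (within the scatter). Compound 3 `CCOC(=O)C1=C(C)NC(C)=C(C(=O)OCC)C1c1ccc(OCC(=O)n2nc(C)cc2C)cc1` replaces the whole amide with a 3,5-dimethyl-1H-pyrazol-1-yl on the carbonyl carbon and gives 46.1%; here a number 16.1 percentage points lower from compound 1 to compound 3 (beyond the scatter), and likewise a number 16.1 percentage points lower from compound 2 to compound 3 (beyond the scatter). Compound 1 thus stands level with compound 2, and the two together are the highest of the three numbers.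

Compound 4 `CCOC(=O)C1=C(C)NC(C)=C(C(=O)OCC)C1c1ccc(OCC(=O)NNC(=O)CCC(=O)O)cc1` is not yet measured. Relative to compound 1 the change is ((2-carboxyethyl)carbonyl)amino in place of 4-methylphenyl on an amide-type nitrogen. For the measured compounds named here, the step that bears on this is the one from compound 1 to compound 2, where a different acylamino group also entered on the same amide-type nitrogen in place of 4-methylphenyl, and the number did not move beyond the scatter. Because no change at the digits printed from compound 1 to compound 2 (within the scatter), compound 4 is expected to stay close to compound 1, with a step of about a number 4.2 percentage points lower from compound 1 to compound 4 (within the scatter). Compound 4 is therefore estimated at 58%, within a range of 45% to 68%.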

Compound 4, a percentage reported as inhibition, in the whole organism at one dose (the size of the read-out at that dose, not a potency): 57.8%
Beside the measured number, compound 4's estimate is 0.2 percentage points above it; the range from low to high includes it.
By their numbers in this assay, from the lowest: compound 3; then compounds 4, 1 and 2 (each within the scatter of the next).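

On the amide-type nitrogen, ((2-carboxyethyl)carbonyl)amino, which has no ring, takes the place of the ring-bearing 4-methylphenyl, and in this assay this gives a number 4.4 percentage points lower from compound 1 to compound 4 (within the scatter) and so shows that the number can hold here without an aromatic ring on this nitrogen. Within the acylamino series, 2-carboxyethyl in place of thiophen-2-yl on a carbonyl carbon gives a number 4.4 percentage points lower from compound 2 to compound 4 (within the scatter) and so extends this to the end of the group, while a number 11.7 percentage points higher from compound 3 to compound 4 (beyond the scatter) shows that the open-chain group also stands apart from the 3,5-dimethyl-1H-pyrazol-1-yl group. No measurement on these compounds accounts for why such different groups give numbers within the scatter of one another.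

The compounds shown leave open whether the carboxylic acid at the end of the chain matters, since an ethyl ester, a primary amine or a longer chain in that place would be needed to tell. They also leave open whether these numbers would stay level at other doses, as each one is a read-out at a single dose and not a potency.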